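Quinazoline series: isopropyl in place of methyl at the two-nitrogen position

The compounds below may be only part of what the source reports. "The series", "measured", "known", "first", "only" and "open" are said of these compounds alone.

Measured so far:
compound 1 `COc1cc2nc(C3CCC3)nc(N3CCN(c4ccccc4C)CC3)c2cc1OC` in an in vitro assay on U2OS cells for agonist activity at neurotensin receptor type 2 (Homo sapiens), read by reporter gene assay and beta-arrestin recruitment (on this read-out higher numbers stand for an effect only at larger amounts of compound and lower numbers for an effect already at smaller amounts), gives > 80000 nM, a limit of the assay.
compound 2 `COc1cc2nc(C3CCC3)nc(N3CCN(c4ccccc4F)CC3)c2cc1OC` gives > 80000 nM, a limit.
compound 3 `COc1cc2nc(C)nc(N3CCN(c4ccccc4OC)CC3)c2cc1OC` gives > 80000 nM, a limit.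

Compound 3 thus stands on no number at all, only at the limit of this assay, and the two other values shown are limits as well; all three sit at the limit of > 80000 nM in this assay, at which 3 of the 3 values shown sit. Among the measured compounds shown here, the single step that can be traced between measured compounds, a step that the two limits leave unreadable from compound 1 to compound 2, is therefore also unreadable in size, since both ends are limits.

Compound 4 `COc1cc2nc(C(C)C)nc(N3CCN(c4ccccc4OC)CC3)c2cc1OC` is not yet measured. Relative to compound 3 it carries isopropyl in place of methyl on an aromatic carbon. For the measured compounds named here, no measured step bears on this change: the one recorded step concerns a substituent on the outer aromatic ring, not the position between two ring nitrogen atoms, and it is itself unreadable. The bulkier variants compound 1 and compound 2 at that position give no signal either.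

Compound 4 is therefore expected to remain at or near the limit in this assay, with an estimated 100000 nM ranging from 30000 nM to 300000 nM, meaning an expected step that the limit leaves unreadable from compound 3 to compound 4 from compound 3, and most likely only a further limit.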

Compound 4, half-maximal effective concentration: > 80000 nM
Compound 4: no number, only a limit; the forecaster's own chance of this, stated with the estimate: 85%; the middle value is on the limit's open side.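

No step can be read from compound 3 to compound 4 in this assay, because both values are limits and not numbers: the limit of > 80000 nM in this assay, at which 4 of the 4 values shown sit.

The compounds shown leave open whether the group between two ring nitrogen atoms has any bearing on the read-out, as none of them gives a number in this assay.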